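From Nitrile to Acetyl on the Aryl Ether

A few compounds are considered here, and "the series" means these few. Any claim that something is new, unique, unknown or untested is made for them only; others in the source may bear on it.

Within the data shown here, compound 2 `N#Cc1ccccc1OC1CCN(c2ccc(-n3ccnc3)nn2)CC1` gives 236 nM in an assay on microsomes from liver for inhibition of acyl-CoA desaturase 1 (Rattus norvegicus) (on this read-out higher numbers stand for weaker inhibition and lower numbers for stronger inhibition), the highest of the two numbers measured so far. Among the measured compounds shown here, its only measured neighbour is compound 1 `FC(F)(F)c1ccccc1OC1CCN(c2ccc(-n3ccnc3)nn2)CC1`, which in this assay gives 4 nM, so that the step of a 59-fold higher number from compound 1 to compound 2 (1.77 log units; beyond the scatter) is a large one, well beyond the scatter. Compound 3 `CC(=O)c1ccccc1OC1CCN(c2ccc(-n3ccnc3)nn2)CC1` has not yet been measured in this assay. It differs from compound 2 by acetyl in place of cyano on an aromatic carbon. For the measured compounds named here, the single measured step that speaks to this position is the large one already described, which shows that the group at this carbon can move the number far in this assay; acetyl, with its three heavy atoms and one hydrogen-bond acceptor, stands apart from both trifluoromethyl and cyano, so the direction is uncertain and the data give no closer guide. Compound 3 is therefore expected to fall between the two measured compounds, with an estimated step of a 3.0-fold lower number from compound 2 to compound 3 (0.47 log units; beyond the scatter) in this assay. The estimated value for compound 3 is 80 nM, within a range from 15 nM to 500 nM.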

Compound 3, half-maximal inhibitory concentration: 34 nM
Beside the measured number, compound 3's estimate is 2.4-fold (0.37 log units) above it; measured number inside the range.
By their numbers in this assay, from the lowest: compound 1; then compound 3; then compound 2.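

Replacing the nitrile with acetyl recovers part of the gap opened by the change from trifluoromethyl to cyano, with a 6.9-fold lower number from compound 2 to compound 3 (0.84 log units; beyond the scatter) in this assay as the reading for this change. Acetyl does not match trifluoromethyl, however, since an 8.5-fold higher number from compound 1 to compound 3 (0.93 log units; beyond the scatter) still separates the two, so among these three compounds the order at this aromatic carbon runs from trifluoromethyl through acetyl to cyano, from the lowest number to the highest, with every gap beyond the scatter. Cyano and acetyl have the same counts of hydrogen-bond donors and acceptors, so those counts do not separate them, and nothing measured here offers an explanation for the order.

These three compounds vary only one aromatic carbon on one shared core, so they leave open whether a group such as an amine, a carboxylic acid or a longer acyl chain would fall within this order or outside it. They also leave open whether the same order would hold with these groups at another carbon of the six-membered aromatic ring.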